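Swapping Methyl for Methoxy on the Amide Phenyl Ring

The compounds below may be only part of what the source reports. "The series", "measured", "known", "first", "only" and "open" are said of these compounds alone.

Three compounds share one core and differ only in the small group on the phenyl ring of the amide. Compound 1 `O=C(CCC(=O)OCCCCCCSc1ccc([N+](=O)[O-])c2nonc12)Nc1ccccc1F` carries a fluoro group there, compound 2 `O=C(CCC(=O)OCCCCCCSc1ccc([N+](=O)[O-])c2nonc12)Nc1ccccc1Cl` a chloro group, and compound 3 `Cc1ccccc1NC(=O)CCC(=O)OCCCCCCSc1ccc([N+](=O)[O-])c2nonc12` a methyl group. In an ADME assay on L02 cells (Homo sapiens) for cytotoxicity, read by MTT assay, with a stated time of 72 h (a lower number here means a stronger inhibitor, a higher number a weaker inhibitor), compound 1 gives 4270 nM, compound 2 gives 5850 nM, and compound 3 gives 9490 nM. Among these numbers compound 3 stands highest: compound 2 lies nearest, and a 1.6-fold higher number from compound 2 to compound 3 (0.21 log units; within the scatter); compound 1 lies furthest, and a 2.2-fold higher number from compound 1 to compound 3 (0.35 log units; beyond the scatter). Between the two halogens, a 1.4-fold higher number from compound 1 to compound 2 (0.14 log units; within the scatter).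

Compound 4 `COc1ccccc1NC(=O)CCC(=O)OCCCCCCSc1ccc([N+](=O)[O-])c2nonc12` differs from compound 3 in one place: methoxy in place of methyl on an aromatic carbon. Going by the values given here, no measured pair swaps methyl for methoxy, so the closest guides are the steps already described among compounds 1, 2 and 3, of which only the change from fluoro to methyl went beyond the scatter, and that only modestly. A change of similar scale is therefore expected here, with no clear direction beyond the scatter. Compound 4 is expected to give 10000 nM, within a range from 4000 nM to 25000 nM. That estimate means a 1.1-fold higher number from compound 3 to compound 4 (0.02 log units; within the scatter), a step expected to stay within the scatter.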

Compound 4, half-maximal inhibitory concentration: 4490 nM
Compound 4: middle estimate off by 2.2-fold (0.35 log units), on the high side; measured number inside the range.
By their numbers in this assay, from the lowest: compounds 1, 4, 2 and 3 (each within the scatter of the next, the first and the last beyond it).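

In this assay, the position ortho to a large group on the amide phenyl ring responds to a change that adds a single oxygen to the methyl group: methoxy in place of methyl gives a modest step beyond the scatter (a 2.1-fold lower number from compound 3 to compound 4 (0.33 log units; beyond the scatter)). Methoxy, the only group here with a hydrogen-bond acceptor by the count given, also stays level with both halogens (a 1.3-fold lower number from compound 2 to compound 4 (0.11 log units; within the scatter); a 1.1-fold higher number from compound 1 to compound 4 (0.02 log units; within the scatter)), so methyl separates from methoxy and fluoro but not from chloro, and compound 2 therefore goes against any picture of methyl standing alone. Nothing among the available data explains why methoxy and methyl part in this way.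

On these data alone, what remains open is whether the oxygen itself matters or only the larger group, which a comparison with an ethyl, ethoxy or hydroxy group at the same position could begin to separate. It is also unknown whether the step from methyl to methoxy would hold with the group elsewhere on the ring, or with a different chain linking the amide to the rest of the shared core.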